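The compounds below may be only part of what the source reports. "The series", "measured", "known", "first", "only" and "open" are said of these compounds alone.

Compound 1 `O=C(O)c1cccc(S(=O)(=O)N2CCC(NS(=O)(=O)c3cc(S(=O)(=O)c4ccccc4)ccc3C(F)(F)F)CC2)c1` gives 190 nM in an assay on U2OS cells for inhibition of secreted frizzled-related protein 1 (Homo sapiens), read by a luciferase reporter, with a stated time of 18 h; on this read-out lower numbers stand for an effect already at smaller amounts and higher numbers for an effect only at larger amounts of compound.
Compound 2 `O=C(O)CCCC(=O)N1CCC(NS(=O)(=O)c2cc(S(=O)(=O)c3ccccc3)ccc2C(F)(F)F)CC1` gives 570 nM in this assay.
Compound 3 `O=C(C1CCNCC1)N1CCC(NS(=O)(=O)c2cc(S(=O)(=O)c3ccccc3)ccc2C(F)(F)F)CC1` gives 150 nM in this assay.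

All three compounds share the same core and differ only in the group on the amine nitrogen in a ring. Compound 3 has the lowest number of the three, but the step of a 1.3-fold lower number from compound 1 to compound 3 (0.10 log units; within the scatter) is within the scatter, so these two cannot be ranked; only compound 2 stands apart, with a 3.8-fold lower number from compound 2 to compound 3 (0.58 log units; beyond the scatter).

Compound 4 `O=C([C@@H]1CCNC1)N1CCC(NS(=O)(=O)c2cc(S(=O)(=O)c3ccccc3)ccc2C(F)(F)F)CC1` takes one step from compound 3: pyrrolidin-3-yl in place of piperidin-4-yl on a carbonyl carbon. The ring that carries the amine shrinks by one carbon, and a stereocentre appears.

Among the measured compounds shown here, none of the measured steps changes a ring size; the steps of a 3.0-fold higher number from compound 1 to compound 2 (0.48 log units; beyond the scatter) and a 1.3-fold lower number from compound 1 to compound 3 (0.10 log units; within the scatter) swap whole groups of different kinds, so they do not speak directly to this change. What they do show is that the two compounds carrying a ring at this position, compound 1 and compound 3, sit close together. With nothing pointing either way, the expected step of a 1.2-fold higher number from compound 3 to compound 4 (0.08 log units; within the scatter) is small and within the scatter. Compound 4 is therefore estimated at 180 nM, with a likely range from 70 nM to 450 nM.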

Compound 4, half-maximal effective concentration: 380 nM
Compound 4: the middle estimate sits 2.1-fold (0.32 log units) below what was measured; the range from low to high includes it.
By their numbers in this assay, from the lowest: compounds 3, 1, 4 and 2 (each within the scatter of the next, the first and the last beyond it).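

The ring on the carbonyl carbon matters at this position: in this assay a five-membered ring in place of a six-membered one, with the hydrogen-bond donor and acceptor counts unchanged, gives a 2.5-fold higher number from compound 3 to compound 4 (0.40 log units; beyond the scatter) and so goes beyond the scatter. Among the compounds shown here, this is the first measured step that keeps the amine-bearing ring and changes only its size and stereocentre, and it shows that even a small edit here can move the number. Compound 4 also loses the clear separation from compound 2 that compound 3 had, since a 1.5-fold lower number from compound 2 to compound 4 (0.18 log units; within the scatter) and a 2.0-fold higher number from compound 1 to compound 4 (0.30 log units; within the scatter) both stay within the scatter, and no data shown here explain the step from compound 3 to compound 4.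

Ring size and the new stereocentre changed together, so the step cannot yet be assigned to either one, and the mirror-image form of pyrrolidin-3-yl would separate the two. An azetidin-3-yl or a piperidin-3-yl on the same carbonyl carbon would show whether the number follows ring size or where the amine sits in the ring.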